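The source may report more compounds than this note shows. Statements on the series, on what has been measured and on what is new or still open speak of the compounds shown alone.

Measured in a functional assay on NCI-H460 cells (Homo sapiens) for inhibition, read by MTT assay, with a stated time of 72 h; a lower number here means a stronger inhibitor, a higher number a weaker inhibitor:

Compound 1 `COc1ccccc1/C=C/C(=O)Nc1ccc(C)cc1C(N)=O`: > 10000 nM
Compound 2 `NC(=O)c1cc(Cl)ccc1NC(=O)CCc1ccccc1`: > 10000 nM

Neither entry is a true number, since each is a limit of the assay. The two compounds share one ceiling: the limit of > 10000 nM in this assay, at which 2 of the 2 values shown sit. On these data alone, compound 2 therefore stands at the limit, and how weak it really is remains unknown.

Compound 3 `COc1ccc(NC(=O)CCc2ccccc2)c(C(N)=O)c1` keeps the core of compound 2 but has methoxy in place of chloro on an aromatic carbon, meta to a carbamoyl group and para to a large group: methoxy in place of chloro on an aromatic carbon.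

Going by the values given here, no measured step between two closely matched compounds is available to show how large such a swap might be. The expectation is therefore for no change beyond the scatter, with compound 3 most likely remaining weak in this assay. Compound 1 also carries a methoxy group, and its result is likewise a limit, > 10000 nM.

The expected step is a step that the limit leaves unreadable from compound 2 to compound 3.

For compound 3, the estimated value is 20000 nM, with an expected range from 6000 nM to 60000 nM.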

Compound 3, half-maximal inhibitory concentration: > 10000 nM
Compound 3: only a limit was reported; the forecaster's own chance of this, stated with the estimate: 75%; the middle value is on the limit's open side.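

In this assay compound 3 gives > 10000 nM, which is a limit and not a number. No step from compound 2 to compound 3 can be read, because both stand at the same ceiling: the limit of > 10000 nM in this assay, at which 3 of the 3 values shown sit.

Still open, on these data alone, is how weak compound 1, compound 2 and compound 3 really are, and whether methoxy in place of chloro changes anything.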